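This account rests on a few compounds, and the source may have more. Where it says the series, first, only, none or still open, it means among the compounds named here.

Compound 3 `CCOC(=O)Nc1cccc(-c2ccc(N(C)C)cc2)c1` stands highest among the three measured compounds in an assay on COS-7 cells for inhibition of patatin-like phospholipase domain-containing protein 2 (Mus musculus), tested at 200 uM (on this read-out higher numbers stand for more inhibition at the one concentration tested (going by the name of the read-out) and lower numbers for less inhibition), where compound 3 gives 93%. Compound 1 `CCOC(=O)c1cccc(-c2ccc(N(C)C)cc2)c1` is its nearest neighbour: in this assay compound 1 gives 87%, and the step of a number 6 percentage points higher from compound 1 to compound 3 (within the scatter) lies within the scatter. Compound 2 `CN(C)c1ccc(-c2cccc(N)c2)cc1` is the furthest: in this assay compound 2 gives 70%, with the step of a number 23 percentage points higher from compound 2 to compound 3 (beyond the scatter) and the step of a number 17 percentage points lower from compound 1 to compound 2 (beyond the scatter).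

Compound 4 `CN(C)c1ccc(-c2cccc(NC(=O)OCc3ccccc3)c2)cc1` differs from compound 3 in one place: phenyl in place of methyl on a saturated chain carbon bound to an oxygen next to a carbonyl group. Among the compounds with values here, none of the measured steps alters this part of the molecule; the three steps exchange the whole group on the aromatic carbon, whereas here only the ethoxy becomes benzyloxy while the (ethoxycarbonyl)amino framework remains. Within the data shown here, the one step that adds the ethoxycarbonyl to the nitrogen, a number 23 percentage points higher from compound 2 to compound 3 (beyond the scatter), was modest, and the read-out for compound 3 already sits near the top of its range. The step of a number 5 percentage points lower from compound 3 to compound 4 (within the scatter) is therefore expected to stay within the scatter. For compound 4 a value of 88% is estimated, expected to fall between 70% and 100%.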

Compound 4, a percentage reported as inhibition, at one concentration (the size of the read-out at that concentration, not a potency): 50%
Compound 4: middle estimate off by 38 percentage points, on the high side, outside the stated range (below it).
By their numbers in this assay, from the lowest: compound 4; then compound 2; then compounds 1 and 3 (each within the scatter of the next).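

This step leaves the framework on the aromatic carbon in place and changes only its outer end, ethoxy to benzyloxy, yet in this assay the result is a number 43 percentage points lower from compound 3 to compound 4 (beyond the scatter). The earlier steps shown here exchanged or added the whole group, so they could not show that the read-out also responds to what sits on the saturated chain carbon bound to an oxygen next to a carbonyl group. Nothing at hand gives a measured reason for this drop.

On these data alone, it remains open whether the aromatic ring itself matters or whether any larger group at this place would do the same; a cyclohexyl group or a longer chain such as butyl would help to separate these two readings. As far as these compounds go, how a smaller change, such as propyl, would fare also remains open.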